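The source may hold more compounds than are shown below. What is called first, only, known or untested is meant among the compounds shown, and "the series" means these compounds.

In an ADME assay on a cell-free system (plasma, Rattus norvegicus) for metabolic stability, read by LC-MS, with a stated time of 60 min, tested at 100 uM (on this read-out lower numbers stand for a less stable compound and higher numbers for a more stable compound), compound 2 `Cc1ccc(C(=O)O)cc1OCCCCOc1ccc(C(=O)CC(C)C)c(O)c1C` gives 96%, and compound 1 `Cc1c(OCCCCOCOc2ccc(C(=O)O)cc2)ccc(C(=O)CC2CCCC2)c1O` gives 100%. For the measured compounds named here, these two values lie within the usual scatter of each other, so compound 2 stands level with the only other measured compound. Compound 3 `Cc1ccc(C(=O)O)cc1OCCCCOc1ccc(C(=O)CC2CCCC2)c(O)c1C` differs from compound 2 in one place: cyclopentyl in place of isopropyl on a saturated chain carbon bound to a carbonyl carbon. This puts cyclopentyl in place of isopropyl on a saturated chain carbon bound to a carbonyl carbon. Going by the values given here, no measured pair isolates this change. However, compound 1, which differs elsewhere too, also carries cyclopentyl and gives 100%, so no step beyond the scatter is expected. The expected step is a number 1 percentage points higher from compound 2 to compound 3 (within the scatter). The estimate for compound 3 is 97%, with an expected range of 88% to 103%.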

Compound 3, percent of the compound remaining: 100%
Estimate against measurement, compound 3: 3 percentage points below, within the range that was stated.
By their numbers in this assay, from the lowest: compounds 2, 1 and 3 (each within the scatter of the next).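

In this assay, for the compounds shown here, the first pair that isolates this position gives a number 4 percentage points higher from compound 2 to compound 3 (within the scatter), so cyclopentyl and isopropyl on a saturated chain carbon bound to a carbonyl carbon stand level. Placing 5-carboxy-2-methylphenyl in place of (4-carboxyphenoxy)methyl on an oxygen on a saturated carbon also leaves the read-out level, with no change at the digits printed from compound 1 to compound 3 (within the scatter). Nothing available explains either result.

Going by these compounds, what an amine or a longer chain would give on this carbon stays open, as does whether any group here would lower the number.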